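The source may report more compounds than this note shows. Statements on the series, on what has been measured and on what is new or still open speak of the compounds shown alone.

Measured compounds:
compound 1 `Cc1nn(C(C)(C)C)c2nc(C(C)C)c(/C=C/[C@@H](O)C[C@@H](O)CC(=O)O)c(-c3ccc(F)cc3)c12` — 86%
compound 2 `Cc1nn(C)c2nc(C3CC3)c(/C=C/[C@@H](O)C[C@@H](O)CC(=O)O)c(-c3ccc(F)cc3)c12` — 74.3%
compound 3 `CC(C)c1nc2c(c(C3CC3)nn2C)c(-c2ccc(F)cc2)c1/C=C/[C@@H](O)C[C@@H](O)CC(=O)O` — 71.3%

All three were run in an in vivo functional assay on the whole organism for inhibition of 3-hydroxy-3-methylglutaryl-coenzyme A reductase (Rattus norvegicus), at a dose of 2 mg/kg by the oral route; a higher number here means a stronger effect of the compound at the dose given, a lower number a weaker effect. Compound 1 gives 86%, the highest of the three numbers; compound 2 at 74.3% lies below it by a margin beyond the scatter, and compound 3 at 71.3% lies further below, also beyond the scatter. No pair of these compounds differs in only one place, so no single step between measured compounds can be read from them.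

The next compound, compound 4 `Cc1nn(-c2ccccc2)c2nc(C(C)C)c(/C=C/[C@@H](O)C[C@@H](O)CC(=O)O)c(-c3ccc(F)cc3)c12`, is derived from compound 1 by one change: phenyl in place of tert-butyl on an aromatic nitrogen. The two compounds carrying a methyl on that nitrogen, compound 2 and compound 3, give the lower numbers, but each also differs from compound 1 elsewhere, so those two values alone say nothing specific about the nitrogen substituent. For the measured compounds named here, with no measured step to anchor this change, the expected step in this assay is a modest decrease, possibly one that stays within the scatter. Compound 4 is accordingly expected to give about 78%, with a range from 62% to 90%. This expectation corresponds to an estimated step of a number 8 percentage points lower from compound 1 to compound 4 (within the scatter).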

Compound 4, a percentage reported as inhibition, in the whole organism at one dose (the size of the read-out at that dose, not a potency): 19.9%
Compound 4: the middle estimate sits 58.1 percentage points above what was measured, and the stated range ends above it.
By their numbers in this assay, from the lowest: compound 4; then compounds 3 and 2 (each within the scatter of the next); then compound 1.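

In this assay the step is a number 66.1 percentage points lower from compound 1 to compound 4 (beyond the scatter), with phenyl in place of tert-butyl on the aromatic nitrogen, so the substituent at this position alone can shift the read-out at this dose by a large margin. The earlier compounds shown here could not show this, as each differs from the others in more than one place. The change exchanges a tert-butyl with no ring, 4 heavy atoms, for a phenyl with one six-membered aromatic ring of carbon only, 6 heavy atoms, but no measurement here bears on why the number falls.

As far as these compounds go, with a single pair, it stays open whether the fall goes with the aromatic ring or with some other difference between the two groups; cyclohexyl on this nitrogen would test a ring without aromaticity, and benzyl would test a phenyl set one carbon away from it. Steps involving the methyl-bearing compounds cannot be read, and a one-dose whole-organism read-out leaves open whether the change acts at the enzyme itself or on what reaches it.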